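Pyridazinone amides on the thienopyrimidine ether: aryl swap notes

This account rests on a few compounds, and the source may have more. Where it says the series, first, only, none or still open, it means among the compounds named here.

Two members of the series have been measured in a functional assay on A549 cells (Homo sapiens) for cytotoxicity, read by MTT assay, with a stated time of 72 h; a lower number here means a stronger inhibitor, a higher number a weaker inhibitor. Compound 1 `Cc1cc(=O)n(-c2cccc(F)c2)nc1C(=O)Nc1ccc(Oc2ncnc3ccsc23)cc1` gives 9540 nM in this assay, and compound 2 `Cc1ccc(-n2nc(C(=O)Nc3ccc(Oc4ncnc5ccsc45)cc3)c(C)cc2=O)cc1`, carrying 4-methylphenyl in place of 3-fluorophenyl on the aromatic nitrogen, gives 11500 nM. Among the measured compounds shown here, the only step measured so far, a 1.2-fold higher number from compound 1 to compound 2 (0.08 log units; within the scatter), lies within the scatter, so compound 2 stands alongside compound 1 with nothing to separate them beyond repeat-measurement noise.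

Compound 3 `Cc1cc(=O)n(-c2ccc(F)c(F)c2)nc1C(=O)Nc1ccc(Oc2ncnc3ccsc23)cc1` is the next variation at the same position: 3,4-difluorophenyl in place of 4-methylphenyl on an aromatic nitrogen. The step from compound 1 to compound 2 bears directly on this change, since it too replaced one aryl group on that aromatic nitrogen with another, and it produced no shift beyond the scatter. Compound 3 is therefore expected to remain close to compound 2 in this assay, with a step of a 1.2-fold lower number from compound 2 to compound 3 (0.08 log units; within the scatter) that is within the scatter, leaning if anything toward the number for compound 1 because 9540 nM was obtained with a fluorinated phenyl at the same position. The estimate for compound 3 is 9500 nM, with a range from 4500 nM to 20000 nM.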

Compound 3, half-maximal inhibitory concentration: 8180 nM
The estimate for compound 3 lay 1.2-fold (0.06 log units) above the measured number; the range from low to high includes it.
By their numbers in this assay, from the lowest: compounds 3, 1 and 2 (each within the scatter of the next).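

Across three aryl groups on the aromatic nitrogen, the numbers in this assay stay together: replacing 4-methylphenyl with 3,4-difluorophenyl gives a 1.4-fold lower number from compound 2 to compound 3 (0.15 log units; within the scatter), so this swap of substituents on the phenyl ring does not separate the two compounds. Compound 3 also supplies the narrowest comparison at this position, as fluoro in place of hydrogen on an aromatic carbon of the 3-fluorophenyl group gives a 1.2-fold lower number from compound 1 to compound 3 (0.07 log units; within the scatter), and a second fluorine therefore leaves compound 3 inseparable from compound 1. No independent measurement is available to explain this flat response in the three compounds.

On these data alone, all three compounds keep a substituted phenyl on the aromatic nitrogen, so it remains open whether a different group there, such as a phenyl bearing a carboxylic acid, a morpholine or a longer chain ending in an amine, would give a step beyond the scatter. As far as these compounds go, the methyl group on the pyridazinone-bearing part of the shared core and the amide hydrogen are also the same throughout, so the response to changes at either place is unknown.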